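The source may report more compounds than this note shows. Statements on the series, on what has been measured and on what is new or still open speak of the compounds shown alone.

Among the compounds with values here, compound 2 `O=C(NC1CCN(Cc2ccn(-c3ccc(C(F)(F)F)cc3)c2)CC1)N1CCCC(CO)C1` gives 23 nM in an assay on HEK293 cells for displacement of a labelled ligand from melanin-concentrating hormone receptor 1 (Homo sapiens) (on this read-out higher numbers stand for weaker inhibition and lower numbers for stronger inhibition), and so stands at the lowest number of the two measured, with compound 1 `O=C(NC1CCN(Cc2ccn(-c3ccc(C(F)(F)F)cc3)c2)CC1)NS(=O)(=O)c1ccc(F)cc1` as its only neighbour at 617 nM. Within the data shown here, the one step on record, a 27-fold lower number from compound 1 to compound 2 (1.43 log units; beyond the scatter), concerns the replacement of the ((4-fluorophenyl)sulfonyl)amino group by a cyclic amine bearing a hydroxymethyl group on the carbonyl carbon; it is large but does not touch the question now at hand.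

Compound 3 `O=C(NC1CCN(Cc2ccn(-c3ccc(C(F)(F)F)cc3)c2)CC1)N1CC[C@@H](O)C1` differs from compound 2 by 3-hydroxypyrrolidin-1-yl in place of 3-(hydroxymethyl)piperidin-1-yl on a carbonyl carbon. This swaps one hydroxy-bearing saturated amine ring for a smaller one carrying the hydroxy group directly on the ring, with donor and acceptor counts unchanged. Among the measured compounds shown here, no measured step in this assay bears on such a ring-size change, so the expectation rests on compound 2 alone and no step beyond the scatter is assumed. Compound 3 is therefore expected to give about 40 nM in this assay, with a range of 12 nM to 150 nM, meaning an estimated step of a 1.7-fold higher number from compound 2 to compound 3 (0.24 log units; within the scatter).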

Compound 3, half-maximal inhibitory concentration: 138 nM
Estimate against measurement, compound 3: 3.5-fold (0.54 log units) below; low and high end bracket the measured number.
By their numbers in this assay, from the lowest: compound 2; then compound 3; then compound 1.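

Replacing 3-(hydroxymethyl)piperidin-1-yl with 3-hydroxypyrrolidin-1-yl on this carbonyl carbon gives a 6.0-fold higher number from compound 2 to compound 3 (0.78 log units; beyond the scatter) in this assay even though the hydrogen-bond donor and acceptor counts stay the same, so this position distinguishes between two hydroxy-bearing saturated amine rings. Measured against the ((4-fluorophenyl)sulfonyl)amino group, 3-hydroxypyrrolidin-1-yl still gives a 4.5-fold lower number from compound 1 to compound 3 (0.65 log units; beyond the scatter) and so keeps only part of the lower number seen with 3-(hydroxymethyl)piperidin-1-yl. Nothing available explains the difference between the two rings.

Ring size and the hydroxy attachment change together in this step, so the contribution of each remains open; 3-hydroxypiperidin-1-yl and 3-(hydroxymethyl)pyrrolidin-1-yl would separate them. Also open, on these data alone, are the opposite stereocentre of 3-hydroxypyrrolidin-1-yl and whether the hydroxy group matters at all, which unsubstituted piperidin-1-yl would address.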